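A few compounds are considered here, and "the series" means these few. Any claim that something is new, unique, unknown or untested is made for them only; others in the source may bear on it.

In a functional assay on NALM-6 cells (Homo sapiens) for cytotoxicity, with a stated time of 72 h (a higher number here means that more compound is needed for the effect, a lower number that less compound is needed), compound 1 `C=C[C@@](C)(/C=C/c1ccc(Nc2ccc(OC)cc2)cc1)CCC=C(C)C` reads > 43400 nM as a limit only. Compound 2 `C=C[C@@](C)(/C=C/c1ccc(Nc2ccc(F)cc2)cc1)CCC=C(C)C` reads > 43400 nM and this too is only a limit. Compound 3 `C=C[C@@](C)(/C=C/c1ccc(Nc2ccc(Cl)c(F)c2)cc1)CCC=C(C)C` reads > 43400 nM and is likewise only a limit, so it cannot be ranked against the others. The evidence amounts to the limit of > 43400 nM in this assay, at which 3 of the 3 values shown sit, and no more. Compound 4 `C=C[C@@](C)(/C=C/c1ccc(Nc2cc(F)c(F)cc2F)cc1)CCC=C(C)C` carries 2,4,5-trifluorophenyl in place of 4-chloro-3-fluorophenyl on a nitrogen on an aromatic ring on the same core. The bearing steps are a step that the two limits leave unreadable from compound 1 to compound 2 and a step that the two limits leave unreadable from compound 1 to compound 3 and a step that the two limits leave unreadable from compound 2 to compound 3 and none has a readable size. No step beyond the scatter is therefore expected in this assay and no direction can be assigned. The estimated step that the limit leaves unreadable from compound 3 to compound 4 is a provisional figure. For compound 4 the expected value is 50000 nM with an estimated range of 25000 nM to 100000 nM and a report as a limit only is the likely outcome.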

Compound 4, half-maximal effective concentration: > 43400 nM
Compound 4: a limit, no number; the forecaster's own chance of this, stated with the estimate: 85%; the middle value does not contradict the limit.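

In this assay compound 4 gives > 43400 nM, a limit only, so its steps from compound 1, compound 2 and compound 3 cannot be read. The compounds shown leave open whether any group on that nitrogen gives a measurable value in this assay.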